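The source may hold more compounds than are shown below. What is called first, only, known or untested is meant among the compounds shown, and "the series" means these compounds.

Measured compounds:
compound 1 `COc1cc(/C(Cl)=C/C=C(\C#N)C(=O)c2c[nH]c3ccccc23)cc(OC)c1OC` gives 21.1%
compound 2 `COc1ccc(/C(Cl)=C/C=C(\C#N)C(=O)c2c(C)[nH]c3ccccc23)cc1` gives 34.2%
compound 3 `COc1ccc(/C(Cl)=C/C=C(\C#N)C(=O)c2c[nH]c3ccc(Br)cc23)cc1` gives 15.6%

In a functional assay for inhibition, with a stated time of 30 min, tested at 1 mM (a higher number here means more inhibition at the concentration tested (going by the name of the read-out), a lower number less inhibition), compound 2 stands highest of the three numbers. Compound 1 lies beyond the scatter below it, and compound 3 lies further below, also beyond the scatter. No pair of measured compounds differs in only one place, so no single step is shown.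

Compound 4 `COc1ccc(/C(Cl)=C/C=C(\C#N)C(=O)c2c(C)[nH]c3ccccc23)cc1OC` differs from compound 2 by methoxy in place of hydrogen on an aromatic carbon. Compound 1, which carries three methoxy groups and lacks the methyl, gives 21.1% in this assay; nothing more is shown for that comparison.

A small downward step or none beyond the scatter is expected in this assay from compound 2 to compound 4. Compound 4 is estimated at 29%, within 15% to 43%, an expected step of a number 5.2 percentage points lower from compound 2 to compound 4 (within the scatter).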

Compound 4, a percentage reported as inhibition, at one concentration (the size of the read-out at that concentration, not a potency): 22.4%
Compound 4: the middle estimate sits 6.6 percentage points above what was measured; low and high end bracket the measured number.
By their numbers in this assay, from the lowest: compounds 3, 1 and 4 (each within the scatter of the next); then compound 2.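

For the compounds shown here, the step of a number 11.8 percentage points lower from compound 2 to compound 4 (beyond the scatter) in this assay is the first single-place change, and it goes beyond the scatter. An added methoxy at this position, ortho to a methoxy group and meta to a large group, therefore lowers inhibition at the concentration tested on the core of compound 2. Nothing available accounts for this loss.

From the compounds shown here alone, whether a hydroxy group, a fluorine atom or an amine at this position would lower inhibition in the same way remains open. So does the size of the methoxy step on a core without the methyl group.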